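A few compounds are considered here, and "the series" means these few. Any claim that something is new, unique, unknown or untested is made for them only; others in the source may bear on it.

Compound 1: `O=C(/C=C/c1cn(-c2ccccc2)nc1-c1ccsc1)c1ccccc1` — 4700 nM
Compound 2: `O=C(/C=C/c1cn(-c2ccccc2)nc1-c1cccnc1)c1cc[nH]c1` — 3300 nM

These two compounds were tested in a functional assay on Huh-7 cells (Homo sapiens) for inhibition, read by sulforhodamine B assay, with a stated time of 72 h; on this read-out lower numbers stand for stronger inhibition and higher numbers for weaker inhibition. Compound 2 has the smaller number of the two, yet the gap to compound 1 is within the usual scatter, so the two cannot be told apart on this basis. Compound 3, `COc1ccc(C(=O)/C=C/c2cn(-c3ccccc3)nc2-c2cccnc2)cc1OC`, has not been measured. It differs from compound 2 by 3,4-dimethoxyphenyl in place of 1H-pyrrol-3-yl on a carbonyl carbon. Going by the values given here, no measured pair shows what such a change does, so nothing beyond the scatter is expected in either direction. For compound 3 the estimated value is 3500 nM, with a range from 1200 nM to 10000 nM, an expected step of a 1.1-fold higher number from compound 2 to compound 3 (0.03 log units; within the scatter).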

Compound 3, half-maximal inhibitory concentration: 3100 nM
Estimate against measurement, compound 3: 1.1-fold (0.05 log units) above, and the stated range covers the measured number.
By their numbers in this assay, from the lowest: compounds 3, 2 and 1 (each within the scatter of the next).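

On the carbonyl carbon, 3,4-dimethoxyphenyl can take the place of 1H-pyrrol-3-yl with a 1.1-fold lower number from compound 2 to compound 3 (0.03 log units; within the scatter) in this assay. The hydrogen-bond donor of the leaving group goes and a larger ring with hydrogen-bond acceptors enters, yet the two compounds cannot be told apart on this read-out. Nothing on hand explains this result. From the compounds shown here alone, whether any group at this place can move the number beyond the scatter remains open. An amine or a carboxylic acid on the ring at this place would test that.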